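This account rests on a few compounds, and the source may have more. Where it says the series, first, only, none or still open, it means among the compounds named here.

Measured in an ADME assay on Vero 76 cells (Chlorocebus sabaeus) for cytotoxicity, read by MTT assay, with a stated time of 96 h; on this read-out higher numbers stand for lower toxicity in this test and lower numbers for higher toxicity in this test:
compound 1 `Cc1ccc(-c2nn(-c3ccccc3)cc2CNc2ccccc2)cc1`: 52000 nM
compound 2 `FC(F)(F)c1ccc(NCc2cn(-c3ccccc3)nc2-c2ccc(C(F)(F)F)cc2)cc1`: 26000 nM
compound 3 `Brc1ccc(NCc2cn(-c3ccccc3)nc2-c2ccc(Br)cc2)cc1`: 88000 nM

On the three numbers shown, compound 1 stands second highest. For the measured compounds named here, its nearest neighbour is compound 3, and its furthest is compound 2; both gaps are within the scatter of this assay, so the three values tell apart no member of the series. Compound 2 and compound 3 each carry a substituent on both outer six-membered rings and still sit beside compound 1.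

Compound 4 `Cc1ccc(-c2nn(-c3ccccc3)cc2CNc2ccc(Cl)cc2)cc1` is not yet measured. It differs from compound 1 in one place: chloro in place of hydrogen on an aromatic carbon; in words, chloro in place of hydrogen on an aromatic carbon, para to a large group. A substituted outer ring of this kind is what compound 2 and compound 3 show, and their values in this assay lie within the scatter of compound 1, so the step in this assay is expected to stay within the scatter, with no clear direction. The expected step is a 1.0-fold lower number from compound 1 to compound 4 (0.02 log units; within the scatter). Compound 4 is therefore estimated at 50000 nM, with a range from 20000 nM to 125000 nM.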

Compound 4, half-maximal cytotoxic concentration: > 100000 nM
Compound 4 was reported as a limit; the forecaster's own chance of this, stated with the estimate: 10%; middle value at least 2.0-fold (0.30 log units) from the limit.
By their numbers in this assay, from the lowest: compounds 2, 1 and 3 (each within the scatter of the next, the first and the last beyond it). At a limit, above all of these: compound 4.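

In this assay compound 4 stands at > 100000 nM and that value is a limit. Chloro in place of hydrogen on an aromatic carbon, para to a large group, gives an at least 1.9-fold higher number from compound 1 to compound 4 (0.28 log units; that floor lies within the scatter) and is the first change in the series read at a single place, though its floor lies within the scatter. The change thus brings no lower number on this read-out, and how far the number rises cannot be told from a value capped in this way: the limit of > 100000 nM in this assay, at which 1 of the 4 values shown sits.

Going by these compounds, whether a methoxy group, an amine or a carboxylic acid at this position would give a number at the same limit stays open. So does the effect of chloro in place of hydrogen on the other outer rings of the core of compound 1.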